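Moving the acid: from compound 2 to compound 3

The source may hold more compounds than are shown below. What is called first, only, known or untested is meant among the compounds shown, and "the series" means these compounds.

Measured so far:
compound 1, `Cc1cc(OCCCCOc2ccc(C(=O)CC(C)C)c(O)c2C)ccc1C(=O)O`: 93.3%
compound 2, `Cc1c(OCCCCOc2ccc(C(=O)O)c(Cl)c2)ccc(C(=O)CC(C)C)c1O`: 80.5%

In an assay on HEK293 cells for positive allosteric modulation of metabotropic glutamate receptor 2 (Rattus norvegicus), read by thallium flux, with a stated time of 2.5 min (on this read-out lower numbers stand for smaller maximal responses and higher numbers for larger maximal responses), compound 2 stands lowest of the two numbers; compound 1 lies a number 12.8 percentage points lower from compound 1 to compound 2 (beyond the scatter) above it. Compound 3, `Cc1c(OCCCCOc2ccccc2C(=O)O)ccc(C(=O)CC(C)C)c1O`, is not yet measured. It differs from compound 2 by 2-carboxyphenyl in place of 4-carboxy-3-chlorophenyl on an oxygen on a saturated carbon. Among the compounds with values here, the one measured step, a number 12.8 percentage points lower from compound 1 to compound 2 (beyond the scatter), concerns chloro in place of methyl on an aromatic carbon; it does not touch the placement of the carboxy group, so it bears only loosely on this change, and the data give no measured step for moving carboxy. The direction of the step to compound 3 in this assay is therefore open. Compound 3 is expected to show a number 2.5 percentage points lower from compound 2 to compound 3 (within the scatter), with the estimate for compound 3 being 78% within a broad range from 50% to 100%.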

Compound 3, largest response reached (reported as percent of maximum), in percent of the reference or control that the assay uses: 92.4%
For compound 3 the middle estimate is 14.4 percentage points below the measured one; measured number inside the range.
By their numbers in this assay, from the lowest: compound 2; then compounds 3 and 1 (each within the scatter of the next).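

In this assay, replacing 4-carboxy-3-chlorophenyl with 2-carboxyphenyl gives a clear gain (a number 11.9 percentage points higher from compound 2 to compound 3 (beyond the scatter)). This shows that the group on this oxygen need not keep its carboxy group where the two earlier compounds had it for the response to stay high. Replacing 4-carboxy-3-methylphenyl with 2-carboxyphenyl gives no distinguishable change (a number 0.9 percentage points lower from compound 1 to compound 3 (within the scatter)), so only the chlorinated group stands apart from the other two. No supporting measurement explains these results.

The step to compound 3 both moves the carboxy group and removes the chlorine, so the compounds shown cannot separate the two changes. As far as these compounds go, it also remains open whether a tetrazole or a primary amide could take the place of the carboxylic acid on this ring.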